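Ortho nitro in place of methylsulfanyl on the phenoxy ring

The compounds below may be only part of what the source reports. "The series", "measured", "known", "first", "only" and "open" are said of these compounds alone.

Measured so far in an assay for inhibition of prostacyclin synthase (Homo sapiens), using microsomes; on this read-out lower numbers stand for stronger inhibition and higher numbers for weaker inhibition:
compound 1 `CC(C)(Oc1ccccc1)C1OCC(C/C=C\CCC(=O)O)C(c2cccnc2)O1` gives 75000 nM.
compound 2 `CC(C)(Oc1ccc(F)cc1)C1OCC(C/C=C\CCC(=O)O)C(c2cccnc2)O1` gives 2000 nM.
compound 3 `CSc1ccccc1OC(C)(C)C1OCC(C/C=C\CCC(=O)O)C(c2cccnc2)O1` reaches the limit of the assay, > 100000 nM.

Compound 3 thus stands at the weak end of the three, with a limit rather than a number; it sits at the limit of > 100000 nM in this assay, at which 1 of the 3 values shown sits. Compared with compound 1, the methylsulfanyl gave an at least 1.3-fold higher number from compound 1 to compound 3 (0.12 log units; that floor lies within the scatter); compared with compound 2 the gap is an at least 50-fold higher number from compound 2 to compound 3 (1.69 log units; beyond the scatter). The only large gain in the series came from the 4-fluorophenyl, a 38-fold lower number from compound 1 to compound 2 (1.57 log units; beyond the scatter).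

Compound 4 `CC(C)(Oc1ccccc1[N+](=O)[O-])C1OCC(C/C=C\CCC(=O)O)C(c2cccnc2)O1` differs from compound 3 by nitro in place of methylsulfanyl on an aromatic carbon. Within the data shown here, no measured step tests a nitro anywhere on this ring, and no step tests any second substituent at this position; the only bearing evidence is that compound 3 with methylsulfanyl at this position gave a limit, > 100000 nM, and that compound 1 with hydrogen there gave 75000 nM. Given this, compound 4 is expected to stay near the weak end, with a step of about a number no higher from compound 3 to compound 4 (the limit leaves the size open) from compound 3 in this assay, i.e. none beyond the scatter. The estimate for compound 4 is 100000 nM, within 30000 nM to 300000 nM, with a fair chance that only a limit is reported.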

Compound 4, half-maximal inhibitory concentration: < 1000 nM
Compound 4: only a limit was reported (the forecaster's own chance of this, stated with the estimate: 50%); middle value at least 100-fold (2.00 log units) away from the limit.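

In this assay, the aromatic carbon ortho to a large group on the phenoxy ring proves able to carry a large gain, which neither compound 1 nor compound 3 had indicated: nitro in place of hydrogen brings an at least 75-fold lower number from compound 1 to compound 4 (1.87 log units; beyond the scatter), and nitro in place of methylsulfanyl brings an at least 100-fold lower number from compound 3 to compound 4 (2.00 log units; beyond the scatter), so the identity of the group at this place decides the outcome, and compound 3 shows that filling it is not enough. Compound 4 is reported only as a limit of the assay, < 1000 nM. Against the 4-fluorophenyl of compound 2 the comparison gives an at least 2.0-fold lower number from compound 2 to compound 4 (0.30 log units; that floor lies within the scatter), so no order between those two is claimed, but a large gain is no longer confined to the single change seen in compound 2.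

From the compounds shown here alone, the actual value of compound 4 remains unknown, and these compounds cannot tell what separates nitro from methylsulfanyl. Also open, going by these compounds, is whether an amine or a nitrile at this place would follow nitro or methylsulfanyl, and what nitro would do at the place held by fluoro in compound 2.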